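Replacing a two-ring group with 4-methoxyphenyl

The source may report more compounds than this note shows. Statements on the series, on what has been measured and on what is new or still open speak of the compounds shown alone.

Measured in a functional assay on PC-9 cells (Homo sapiens) for inhibition, read by MTT assay, with a stated time of 72 h; a higher number here means a weaker inhibitor, a lower number a stronger inhibitor:
Compound 1 `Cc1cc(Nc2ccn(Cc3cccc4ccccc34)n2)n2nc(SCc3ccc(Br)cc3)nc2n1`: 5660 nM
Compound 2 `Cc1cc(Nc2ccn(Cc3csc4ccc(Cl)cc34)n2)n2nc(SCc3ccc(Br)cc3)nc2n1`: 4350 nM

For the measured compounds named here, with only two compounds measured, compound 2 cannot be told apart from compound 1, since the single step between them (a 1.3-fold lower number from compound 1 to compound 2 (0.11 log units; within the scatter)) lies within the scatter. That step exchanged naphthalen-1-yl for 5-chloro-1-benzothiophen-3-yl on a saturated chain carbon bound to an aromatic nitrogen, and the next change falls at the same place. Compound 3 `COc1ccc(Cn2ccc(Nc3cc(C)nc4nc(SCc5ccc(Br)cc5)nn34)n2)cc1` keeps the shared core but carries 4-methoxyphenyl in place of 5-chloro-1-benzothiophen-3-yl (4-methoxyphenyl in place of 5-chloro-1-benzothiophen-3-yl on a saturated chain carbon bound to an aromatic nitrogen). Going by the values given here, the measured step is the only guide here, and it is a limited one: both of its groups contain two aromatic rings, whereas 4-methoxyphenyl contains one. Among the compounds with values here, no measured compound shows what that loss does in this assay, so the expectation is for no step beyond the scatter, held with wide uncertainty. The expected change is small (a 1.4-fold higher number from compound 2 to compound 3 (0.14 log units; within the scatter)). For compound 3 the estimated value is 6000 nM, with an expected range from 2500 nM to 15000 nM.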

Compound 3, half-maximal inhibitory concentration: > 50000 nM
Compound 3 ended at the assay's limit; the forecaster's own chance of this, stated with the estimate: 8%; middle value at least 8.3-fold (0.92 log units) from the limit.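

The first two compounds suggested that this place, the saturated chain carbon bound to an aromatic nitrogen, might tolerate a change of group, since exchanging one two-ring group for another gave no step beyond the scatter in this assay. The single-ring 4-methoxyphenyl group shows that this tolerance has a limit, with a large step, an at least 11-fold higher number from compound 2 to compound 3 (1.06 log units; beyond the scatter), and a clear loss against the naphthalen-1-yl group as well, an at least 8.8-fold higher number from compound 1 to compound 3 (0.94 log units; beyond the scatter). The value of compound 3 is a limit of the assay and not a number, so the full size of both steps stays unknown: the limit of > 50000 nM in this assay, at which 1 of the 3 values shown sits.

Compound 3 both loses the second aromatic ring and gains a methoxy group, so the compounds shown do not reveal whether either change alone accounts for the loss. An unsubstituted phenyl or a 4-chlorophenyl at this place would help separate the two, and a methoxy group on a naphthalen-1-yl would test the other half of the question.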